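This account rests on a few compounds, and the source may have more. Where it says the series, first, only, none or still open, it means among the compounds named here.

Of the compounds shown here, two that share a common core have so far been measured in an assay on HEK293 cells for inhibition of Steryl-sulfatase (Homo sapiens), tested at 1 uM; a higher number here means a stronger effect of the compound at the concentration tested, a lower number a weaker effect. Compound 1 `CCN(Cc1cccc(Br)c1)c1ccc(C(=O)N2CCc3ccc(OS(N)(=O)=O)cc3C2)cc1` gives 97.2% in this assay, and compound 2 `CCN(Cc1ccc(Br)cc1)c1ccc(C(=O)N2CCc3ccc(OS(N)(=O)=O)cc3C2)cc1` gives 95.9%. Among the compounds with values here, the only step between them, a number 1.3 percentage points lower from compound 1 to compound 2 (within the scatter), exchanges 4-bromophenyl for 3-bromophenyl on a saturated chain carbon bound to a nitrogen on an aromatic ring. Compound 2 therefore stands with the lower of the two numbers, but the gap to compound 1 lies within the scatter, so no order between the two can be claimed.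

Compound 3 `CCN(Cc1ccccc1)c1ccc(C(=O)N2CCc3ccc(OS(N)(=O)=O)cc3C2)cc1` has not yet been measured. It differs from compound 2 by hydrogen in place of bromo on an aromatic carbon. Within the data shown here, no measured step removes a bromo group, so the change has no direct precedent. Among the measured compounds shown here, the one step that touches the same benzyl group, a number 1.3 percentage points lower from compound 1 to compound 2 (within the scatter), stayed within the scatter, and compound 3 is therefore expected to move little beyond the scatter: a number 2.9 percentage points lower from compound 2 to compound 3 (within the scatter). Compound 3 is estimated at 93%, with a range from 78% to 99%.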

Compound 3, a percentage reported as inhibition, at one concentration (the size of the read-out at that concentration, not a potency): 83.6%
Compound 3: middle estimate off by 9.4 percentage points, on the high side; low and high end bracket the measured number.
By their numbers in this assay, from the lowest: compound 3; then compounds 2 and 1 (each within the scatter of the next).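

Once the bromo group is gone from the aromatic carbon para to a large group, the number in this assay drops beyond the scatter (a number 12.3 percentage points lower from compound 2 to compound 3 (beyond the scatter)), and the comparison with the 3-bromophenyl compound reads the same way (a number 13.6 percentage points lower from compound 1 to compound 3 (beyond the scatter)). The earlier step between compound 1 and compound 2 (a number 1.3 percentage points lower from compound 1 to compound 2 (within the scatter)) had shown only that moving the bromo group left no readable difference, whereas these steps show that the benzyl group is not indifferent to this change: both bromo compounds stand beyond the scatter above the plain phenyl of compound 3, and none of the three compounds goes against this. Nothing available explains why the presence of the bromo group counts here.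

The compounds shown leave open whether this gain belongs to bromo itself or would also come with chloro, methyl or methoxy on the same aromatic carbon. They also leave open how a longer chain in place of the ethyl group on the nitrogen would bear on the number, and a read-out at one concentration gives no potency for any of the three.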